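Series notes: trifluoromethyl added on compound 1

The source may hold more compounds than are shown below. What is called first, only, known or untested is meant among the compounds shown, and "the series" means these compounds.

Three compounds of the shared core carry numbers in a functional assay on PC-12 cells (Rattus norvegicus) for cytotoxicity, read by MTT assay, with stated times of 2 h and 24 h, tested at 10 uM; on this read-out lower numbers stand for a weaker effect and higher numbers for a stronger effect at the one concentration tested. Compound 1 `Oc1cc(C(F)(F)F)ccc1-c1nc(-c2ccccc2O)n(-c2cccc(C(F)(F)F)c2)n1` gives 99.9% in this assay. Compound 2 `COc1cccc(-n2nc(-c3ccc(C(F)(F)F)cc3O)nc2-c2ccccc2O)c1` gives 106%, and compound 3 `Oc1cc(C(F)(F)F)ccc1-c1nc(-c2ccccc2O)n(-c2ccc(Cl)cc2Cl)n1` gives 95.2%. Compound 1 stands second highest of the three: its nearest neighbour is compound 3, reached by a number 4.7 percentage points lower from compound 1 to compound 3 (within the scatter), and the furthest is compound 2, reached by a number 6.1 percentage points higher from compound 1 to compound 2 (within the scatter); both of these steps stay within the scatter. Among the compounds with values here, the one step beyond the scatter is a number 10.8 percentage points lower from compound 2 to compound 3 (beyond the scatter), a modest one.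

The next compound, compound 4 `Oc1cc(C(F)(F)F)ccc1-c1nc(-c2ccccc2O)n(-c2cc(C(F)(F)F)cc(C(F)(F)F)c2)n1`, differs from compound 1 by trifluoromethyl in place of hydrogen on an aromatic carbon. The change sits on the ring attached to the aromatic nitrogen, the same ring that was exchanged in the steps from compound 1 to compound 3 and from compound 2 to compound 3. Those exchanges moved the read-out little: one within the scatter, one modest. A single added trifluoromethyl on that ring is therefore expected to give no step beyond the scatter in this assay. The expected step is a number 1.9 percentage points lower from compound 1 to compound 4 (within the scatter). Compound 4 is estimated at 98% in this assay, with a range from 86% to 109%.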

Compound 4, a percentage reported as activity, at one concentration (the size of the read-out at that concentration, not a potency): 86.2%
The estimate for compound 4 lay 11.8 percentage points above the measured number, and the stated range covers the measured number.
By their numbers in this assay, from the lowest: compounds 4, 3, 1 and 2 (each within the scatter of the next, the first and the last beyond it).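

In this assay, adding a second trifluoromethyl to the ring on the aromatic nitrogen gives a number 13.7 percentage points lower from compound 1 to compound 4 (beyond the scatter), a modest step and the first from compound 1 to pass beyond the scatter. The earlier steps shown here from compound 1 exchanged one group for another, either on that ring or by replacing the whole ring, and neither moved the read-out beyond the scatter; here, trifluoromethyl in place of hydrogen, meta to a trifluoromethyl group, does, so this aromatic carbon is not silent. Nothing available bears on why the number falls with this change.

A single group at this position cannot show whether the step belongs to trifluoromethyl itself or to the pairing with the trifluoromethyl group already on the ring, and a compound carrying only the new group on that ring would separate the two. Also open, on these data alone, is whether an amine or a carboxylic acid on the same aromatic carbon would give a step of similar size and direction, or none beyond the scatter.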